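Group exchange on the shared core: compound 2 to compound 3

This account rests on a few compounds, and the source may have more. Where it says the series, first, only, none or still open, it means among the compounds named here.

Measured so far:
- compound 1 `COc1cc(-n2cnc3ccc(-c4ccc(C)cc4F)cc32)cc(OC)c1OC`: 5650 nM
- compound 2 `COc1cc(-n2cnc3ccc(-c4ccc(C(F)(F)F)cc4)cc32)cc(OC)c1OC`: 890 nM

In a functional assay on SGC-7901 cells (Homo sapiens) for antiproliferative activity, read by MTT assay, with a stated time of 72 h (a higher number here means a weaker inhibitor, a lower number a stronger inhibitor), compound 2 stands lowest of the two, at 890 nM. The next structure, compound 3 `COc1cc(-n2cnc3ccc(-c4cccc(N)c4)cc32)cc(OC)c1OC`, keeps the shared core and carries 3-aminophenyl in place of 4-(trifluoromethyl)phenyl on an aromatic carbon.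

Within the data shown here, only one measured step bears on this change: a 6.3-fold lower number from compound 1 to compound 2 (0.80 log units; beyond the scatter). It is also an exchange of the group on that aromatic carbon, so it gives a gauge of size for such an exchange. Its direction does not carry over, since neither measured compound has an amino group. Compound 2 sits at the low end of just two values, so a modest move to a higher number in this assay is expected, no larger than about the size of that one step, with wide uncertainty. The estimated change is a 2.2-fold higher number from compound 2 to compound 3 (0.35 log units; beyond the scatter). For compound 3 the estimated value is 2000 nM, with an expected range from 350 nM to 9000 nM.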

Compound 3, half-maximal inhibitory concentration: 21 nM
Estimate against measurement, compound 3: 95-fold (1.98 log units) above; measured number below the stated range.
By their numbers in this assay, from the lowest: compound 3; then compound 2; then compound 1.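

In this assay the exchange at this aromatic carbon reaches much further than the earlier pair suggested: a 42-fold lower number from compound 2 to compound 3 (1.63 log units; beyond the scatter) and a 270-fold lower number from compound 1 to compound 3 (2.43 log units; beyond the scatter) are both large, whereas a 6.3-fold lower number from compound 1 to compound 2 (0.80 log units; beyond the scatter) is modest. The earlier compounds showed only that the group on this carbon matters; compound 3 shows that the shared core can reach far lower numbers in this series with 3-aminophenyl at this place, and this is the only group shown that brings a hydrogen-bond donor and a hydrogen-bond acceptor. No measurement at hand bears on what lies behind this large drop.

The single exchange removes 4-(trifluoromethyl)phenyl and installs 3-aminophenyl in one move, so the compounds shown do not separate the contribution of the amine from that of losing the trifluoromethyl group or from where the substituent sits on the phenyl ring. Nor do they tell whether a hydroxyl, a methylamino group or an acetamide in place of the amine would hold the number of compound 3, which is what would test how specific this result is to the amine.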